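The source may hold more compounds than are shown below. What is called first, only, known or untested is meant among the compounds shown, and "the series" means these compounds.

Of the compounds shown here, three have so far been tested in a functional assay on the whole organism (strain NMRI) with Mus musculus as the target, with a stated time of 4 h; on this read-out higher numbers stand for an effect only at larger amounts of compound and lower numbers for an effect already at smaller amounts. Compound 2 `Cc1ccc(-c2nc3ccc(Br)cn3c2/C=N/OCc2cn(Cc3ccc([N+](=O)[O-])cc3)nn2)cc1` gives 20 mg/kg, the lowest of the three numbers. Compound 3 `Cc1cccn2c(/C=N/O)c(-c3ccc(F)cc3)nc12`, which carries the bare oxime on its core, gives 40 mg/kg in this assay; the gap between compound 2 and compound 3 lies within the scatter, so the two cannot be told apart. Compound 1 `COc1ccc(Cn2cc(CO/N=C/c3c(-c4ccccc4)nc4c(C)cccn34)nn2)cc1` gives 100 mg/kg in this assay, a larger dose than compound 2 needs, and this gap lies beyond the scatter. Compound 1 also differs from compound 2 in its core, so no single group can be held responsible for that gap.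

Compound 4 `COc1ccc(Cn2cc(CO/N=C/c3c(-c4ccc(C)cc4)nc4ccc(Br)cn34)nn2)cc1` is compound 2 with one change: methoxy in place of nitro on an aromatic carbon. Among the compounds with values here, no pair of measured compounds differs in this place alone, so the size of such a step is not known from direct comparison. Within the data shown here, the only hint is that compound 1 carries the same 4-methoxybenzyl and gives 100 mg/kg in this assay, but its core is different too. The step is expected to be modest, toward a somewhat larger dose, and possibly not beyond the scatter: a 2.0-fold higher number from compound 2 to compound 4 (0.30 log units; within the scatter). Compound 4 is therefore estimated to give about 40 mg/kg in this assay, within a range from 15 mg/kg to 100 mg/kg.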

Compound 4, minimum effective dose: 40 mg/kg
Beside the measured number, compound 4's estimate shows no gap at the digits printed; the measured number falls inside the stated range.
By their numbers in this assay, from the lowest: compounds 2, 3 and 4 (each within the scatter of the next); then compound 1.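

Within the data shown here, compounds 2 and 4 share everything except one group, so they give the first reading of a single change in this assay: methoxy in place of nitro, on an aromatic carbon of the benzyl ring, gives a 2.0-fold higher number from compound 2 to compound 4 (0.30 log units; within the scatter) and so no difference that can be told from ordinary repeat variation. This position therefore carries either a nitro group or a methoxy group without a clear shift in the dose needed, so on this evidence the nitro group is not required for an effect in this dose range. Nothing available explains why the two groups read alike.

From the compounds shown here alone, whether this tolerance extends further remains open, as a single pair cannot show how an amine, a carboxylic acid or a longer chain such as butoxy would behave on the same ring carbon. Going by these compounds, the steps to compound 1 and compound 3 cannot be read because those compounds differ from the others in more than one place, so the contribution of each part of the core also remains unknown.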